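This account rests on a few compounds, and the source may have more. Where it says the series, first, only, none or still open, it means among the compounds named here.

Working notes on the series. In a functional assay on HeLa cells (Homo sapiens) for cytotoxicity, read by WST assay, with a stated time of 48 h (on this read-out lower numbers stand for stronger inhibition and higher numbers for weaker inhibition), compound 1 `COC[C@H](C(C)C)C(c1ccc(O)c(OC)c1)c1ccc(O)c(OC)c1` gives 76000 nM and compound 2 `COC[C@@H](C(C)C)C(c1ccc(O)c(OC)c1)c1ccc(O)c(OC)c1` gives 69000 nM, so compound 2 stands level with compound 1 within the scatter. The next structure is compound 3 `CC[C@H](C(C)C)C(c1ccc(O)c(OC)c1)c1ccc(O)c(OC)c1`, and the change is 1-isopropylpropyl in place of 1-(methoxymethyl)-2-methylpropyl on a saturated chain carbon bound to two aromatic carbons. Among the measured compounds shown here, only one measured step exists, a 1.1-fold lower number from compound 1 to compound 2 (0.04 log units; within the scatter), and it lies within the scatter. It bears only indirectly on this change, given (the fact that compounds 1 and 2 differ only in the configuration as drawn). For the measured compounds named here, no measured step exchanges this group, so the expectation rests on compound 2 at 69000 nM, and no step beyond the scatter is expected in this assay. The estimated step is a 1.2-fold lower number from compound 2 to compound 3 (0.06 log units; within the scatter). The expected value for compound 3 is 60000 nM, with an estimated range of 25000 nM to 130000 nM.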

Compound 3, half-maximal inhibitory concentration: 9700 nM
Compound 3: the middle estimate sits 6.2-fold (0.79 log units) above what was measured, outside the stated range (below it).
By their numbers in this assay, from the lowest: compound 3; then compounds 2 and 1 (each within the scatter of the next).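

In this assay, the group on the saturated chain carbon bound to two aromatic carbons proves able to move the number: 1-isopropylpropyl in place of 1-(methoxymethyl)-2-methylpropyl gives a 7.1-fold lower number from compound 2 to compound 3 (0.85 log units; beyond the scatter), and methyl in place of methoxy, read against the other configuration, gives a 7.8-fold lower number from compound 1 to compound 3 (0.89 log units; beyond the scatter). Both steps lie beyond the scatter, whereas the one earlier step, a 1.1-fold lower number from compound 1 to compound 2 (0.04 log units; within the scatter), lies within it and could say nothing about this group: the fact that compounds 1 and 2 differ only in the configuration as drawn

The compounds shown leave open whether the step follows the loss of the methoxy oxygen or the shortening of the chain, which an ethoxy group or an amine in place of methoxy would help to separate. From the compounds shown here alone, whether configuration matters with 1-isopropylpropyl also stays open, as only compound 3 carries this group.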